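The compounds below may be only part of what the source reports. "The series", "measured", "known", "first", "only" and "open" are said of these compounds alone.

Compound 3 `O=C(N[C@@H](CC1CC1)C(=O)N[C@@H](C[C@@H]1CCNC1=O)C(O)S(=O)(=O)O)OCc1ccccc1` is one of three compounds that have been tested in an ADME assay on Vero C1008 cells (Chlorocebus sabaeus) for cytotoxicity, read by luminescence and CellTiter-Glo, with a stated time of 24 h; on this read-out lower numbers stand for higher toxicity in this test and higher numbers for lower toxicity in this test. In this assay compound 3 gives > 200000 nM, which is a limit of the test rather than a number. Compound 1 `O=C[C@H](C[C@@H]1CCNC1=O)NC(=O)[C@H](CC1CC1)NC(=O)OCc1ccccc1` gives > 200000 nM, likewise a limit. Compound 2 `O=C[C@H](C[C@@H]1CCNC1=O)NC(=O)[C@H](CC1CC1)NC(=O)OCc1cccc(F)c1` gives > 200000 nM, also a limit. Every value shown here is the limit of > 200000 nM in this assay, at which 3 of the 3 values shown sit, so compound 3 stands at the same limit as the other two, and no order among the three can be read.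

Compound 4 `O=C(N[C@@H](CC1CC1)C(=O)N[C@@H](C[C@@H]1CCNC1=O)C(O)S(=O)(=O)O)OCc1cccc(F)c1` has not yet been measured. It differs from compound 3 by fluoro in place of hydrogen on an aromatic carbon. The same change was made once before, from compound 1 to compound 2: a step that the two limits leave unreadable from compound 1 to compound 2. The step that links compound 1 to compound 3, a step that the two limits leave unreadable from compound 1 to compound 3, is unreadable as well. Neither measured step gives a size or a direction, so there is nothing that points to a step beyond the scatter, and with the limit of > 200000 nM in this assay, at which 3 of the 3 values shown sit, reached by all three values the expectation is that compound 4 will reach it too. The expected step is a step that the limit leaves unreadable from compound 3 to compound 4. Compound 4 is estimated at 300000 nM, within 150000 nM to 1000000 nM, and is most likely to be reported again only as a limit.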

Compound 4, half-maximal cytotoxic concentration: > 200000 nM
Compound 4: no number, only a limit; the forecaster's own chance of this, stated with the estimate: 85%; the middle value does not contradict the limit.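

No new step can be read for compound 4: its steps from compound 3 and from compound 2 each join two limits, and the whole set stands at one limit: the limit of > 200000 nM in this assay, at which 4 of the 4 values shown sit.

From the compounds shown here alone, with no number for any of the four compounds, it stays open whether fluoro or hydroxy(sulfo)methyl changes the cytotoxic concentration in this assay at all.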